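The source may hold more compounds than are shown below. What is called first, only, known or untested is meant among the compounds shown, and "the series" means these compounds.

Compound 1 `Cn1c(=O)c2c(nc(Sc3ccccc3)n2C)n(C)c1=O`: 33200 nM
Compound 2 `Cn1c(=O)c2c(nc(SCc3ccc(Cl)cc3)n2C)n(C)c1=O`: 192 nM
Compound 3 `CC(C)CCSc1nc2c(c(=O)n(C)c(=O)n2C)n1C`: 2620 nM

All three were tested in an assay on isolated protein for inhibition of Amine oxidase [flavin-containing] B (Homo sapiens), read by fluorescence; a lower number here means a stronger inhibitor, a higher number a weaker inhibitor. Among them compound 3 stands second highest: the nearest number belongs to compound 1, the furthest to compound 2. Two measured steps change the group carried by the same sulfur, and both are large: a 13-fold lower number from compound 1 to compound 3 (1.10 log units; beyond the scatter), and a 14-fold higher number from compound 2 to compound 3 (1.14 log units; beyond the scatter). Compound 4 `Cn1c(=O)c2c(nc(SC3CCCC3)n2C)n(C)c1=O` differs from compound 3 by cyclopentyl in place of isopentyl on a sulfur. Neither earlier step puts a saturated ring directly on the sulfur; the branched chain of compound 3 is the closest match available, so the change should weigh less than those two steps. Compound 4 is therefore expected to land close by, the step being estimated as a 1.3-fold lower number from compound 3 to compound 4 (0.12 log units; within the scatter). The estimate for compound 4 in this assay is 2000 nM, within 500 nM to 8000 nM.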

Compound 4, half-maximal inhibitory concentration: 20900 nM
Compound 4: middle estimate off by 10-fold (1.02 log units), on the low side; measured number outside the range, above it.
By their numbers in this assay, from the lowest: compound 2; then compound 3; then compounds 4 and 1 (each within the scatter of the next).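

Swapping isopentyl for cyclopentyl on the sulfur gives an 8.0-fold higher number from compound 3 to compound 4 (0.90 log units; beyond the scatter), so this position separates two groups that have the same count of carbons and no hydrogen-bond donors or acceptors. Ring closure alone, with no change in that count, is enough to alter the number. Cyclopentyl and phenyl on this sulfur, by contrast, are separated only by a 1.6-fold lower number from compound 1 to compound 4 (0.20 log units; within the scatter), so a ring of either kind placed directly there reads alike. Still open, as far as these compounds go, is whether a cyclopropyl ring or a straight pentyl chain on this sulfur would fall nearer compound 3 or compound 4. Nothing available accounts for the difference between the ring and the branched chain.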